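Swapping the Ether Substituent on the Shared Core

The compounds below may be only part of what the source reports. "The series", "measured", "known", "first", "only" and "open" are said of these compounds alone.

Measured compounds in a functional assay on HEK293 cells for agonist activity at G-protein coupled receptor 39 (Homo sapiens), read by scintillation proximity assay and inositol phosphate accumulation, with a stated time of 75 min, in the presence of a further agent that is not named here; on this read-out higher numbers stand for an effect only at larger amounts of compound and lower numbers for an effect already at smaller amounts:
compound 1, `Cc1nn(-c2ncnc3nc[nH]c23)c2c1C(OC1CCCC1)CC(=O)N2`, 2 nM
compound 2, `Cc1nn(-c2ncnc3nc[nH]c23)c2c1C(OCc1ccccc1F)CC(=O)N2`, 4 nM

Compound 2 carries the 2-fluorobenzyl ether; compound 1 carries the cyclopentyl ether on the same oxygen. Going by the values given here, the only step among the measured compounds, a 2.0-fold higher number from compound 1 to compound 2 (0.30 log units; within the scatter), lies within the scatter, so the two numbers cannot be told apart. Compound 3, `Cc1cc(C)n(CCOC2CC(=O)Nc3c2c(C)nn3-c2ncnc3nc[nH]c23)n1`, differs from compound 2 in that ((3,5-dimethyl-1H-pyrazol-1-yl)methyl in place of 2-fluorophenyl on a saturated chain carbon bound to an oxygen on a saturated carbon). Among the compounds with values here, the one measured step that bears on this change is the exchange of the group on the same oxygen, a 2.0-fold higher number from compound 1 to compound 2 (0.30 log units; within the scatter), which produced no difference beyond the scatter. Since the entering group is of another kind than either ether substituent measured so far, the range is set wide, but no step beyond the scatter is expected, and the step from compound 2 is estimated as a 1.8-fold higher number from compound 2 to compound 3 (0.24 log units; within the scatter). Compound 3 is therefore expected to give about 7 nM in this assay, within 2 nM to 35 nM.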

Compound 3, half-maximal effective concentration: 16 nM
Estimate against measurement, compound 3: 2.3-fold (0.36 log units) below; measured number inside the range.
By their numbers in this assay, from the lowest: compounds 1 and 2 (each within the scatter of the next); then compound 3.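

In this assay, the group on this oxygen proves able to shift the number beyond the scatter, which the earlier exchange did not show: 2-(3,5-dimethyl-1H-pyrazol-1-yl)ethyl gives modest steps from both earlier ethers (a 4.0-fold higher number from compound 2 to compound 3 (0.60 log units; beyond the scatter); an 8.0-fold higher number from compound 1 to compound 3 (0.90 log units; beyond the scatter)). The cyclopentyl and 2-fluorobenzyl ethers cannot be told apart, so among the three compounds only the ether with the five-membered aromatic ring stands apart, on the side of higher numbers. Nothing at hand explains this change.

The compounds shown leave open whether the step follows the dimethylpyrazole ring or the ethyl chain that carries it, a question that a 2-phenylethyl group on the same oxygen would address. On these data alone, how a 2-aminoethyl or 2-carboxyethyl group would read out at this position also remains open.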